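A few compounds are considered here, and "the series" means these few. Any claim that something is new, unique, unknown or untested is made for them only; others in the source may bear on it.

Compound 1 `Cc1ccc(NC(=S)NC(=O)c2ccc(OCc3ccc(C(F)(F)F)cc3)cc2)cc1-c1nc2ccccc2[nH]1`: 17600 nM; compound 2 `Cc1ccc(NC(=S)NC(=O)c2ccc(OCc3cccc(C(F)(F)F)c3)cc2)cc1-c1nc2ccccc2[nH]1`: 8200 nM; compound 3 `Cc1ccc(NC(=S)NC(=O)c2ccc(OCc3cccc(Cl)c3Cl)cc2)cc1-c1nc2ccccc2[nH]1`: 63700 nM; compound 4 `Cc1ccc(NC(=S)NC(=O)c2ccc(OCc3ccc(Cl)c(Cl)c3)cc2)cc1-c1nc2ccccc2[nH]1`: not yet measured.

In a functional assay on HT-29 cells (Homo sapiens) for inhibition, read by MTT assay, with a stated time of 48 h (a higher number here means a weaker inhibitor, a lower number a stronger inhibitor), compound 3 gives the highest number of the three, so it is the weakest inhibitor here. The move to compound 4 is 3,4-dichlorophenyl in place of 2,3-dichlorophenyl on a saturated chain carbon bound to an oxygen on an aromatic ring. Within the data shown here, no measured step covers this exact rearrangement. The nearest guides are a 3.6-fold higher number from compound 1 to compound 3 (0.56 log units; beyond the scatter) and a 7.8-fold higher number from compound 2 to compound 3 (0.89 log units; beyond the scatter), both showing the 2,3-dichlorophenyl compound weaker than compounds carrying one group at another position. By that reasoning a lower number is expected for compound 4, a modest step: a 3.5-fold lower number from compound 3 to compound 4 (0.55 log units; beyond the scatter). Compound 4 is therefore estimated at 18000 nM, within a range from 6000 nM to 55000 nM.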

Compound 4, half-maximal inhibitory concentration: 6270 nM
Compound 4: the middle estimate sits 2.9-fold (0.46 log units) above what was measured, within the range that was stated.
By their numbers in this assay, from the lowest: compounds 4 and 2 (each within the scatter of the next); then compound 1; then compound 3.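

In this assay, rearranging the same two chlorines from 2,3-dichlorophenyl to 3,4-dichlorophenyl gives a 10-fold lower number from compound 3 to compound 4 (1.01 log units; beyond the scatter), so at this place the arrangement on the ring counts, not only which atoms it carries. Against the trifluoromethyl compounds, the change gives a 2.8-fold lower number from compound 1 to compound 4 (0.45 log units; beyond the scatter) and a 1.3-fold lower number from compound 2 to compound 4 (0.12 log units; within the scatter), the latter leaving the two compounds level. Nothing available explains these differences.

Still open, as far as these compounds go, is how a ring carrying an amine or a carboxylic acid would behave here. A longer chain at this place also remains untested in the compounds shown.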